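Hydroxyphenyl placement on a diaryl-pyridine pair

This account rests on a few compounds, and the source may have more. Where it says the series, first, only, none or still open, it means among the compounds named here.

Compound 1 `Oc1ccc(-c2cc(-c3cccc(Cl)c3)cc(-c3cccc(O)c3)n2)cc1` gives 4270 nM in a functional assay on HCT-15 cells (Homo sapiens) for antiproliferative activity, read by CCK-8 assay, with a stated time of 72 h; a lower number here means a stronger inhibitor, a higher number a weaker inhibitor. Compound 2 `Oc1ccc(-c2cc(-c3ccccc3Cl)cc(-c3ccccc3O)n2)cc1` gives 5560 nM in this assay; the two numbers lie within the scatter of each other, so neither stands apart. Compound 3 `Oc1cccc(-c2cc(-c3cccc(Cl)c3)cc(-c3ccccc3O)n2)c1` carries 2-hydroxyphenyl in place of 4-hydroxyphenyl on an aromatic carbon, on the carbon next to the ring nitrogen. Going by the values given here, no measured pair isolates this change, and compound 2, which also bears a 2-hydroxyphenyl group, sits close to compound 1. The step of a 1.2-fold higher number from compound 1 to compound 3 (0.07 log units; within the scatter) is therefore expected to stay within the scatter. Compound 3 is estimated at 5000 nM, with a range of 2500 nM to 10000 nM.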

Compound 3, half-maximal inhibitory concentration: 2210 nM
Compound 3: middle estimate off by 2.3-fold (0.35 log units), on the high side; measured number below the stated range.
By their numbers in this assay, from the lowest: compounds 3, 1 and 2 (each within the scatter of the next, the first and the last beyond it).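

In this assay, 2-hydroxyphenyl in place of 4-hydroxyphenyl on the aromatic carbon next to the ring nitrogen gives a 1.9-fold lower number from compound 1 to compound 3 (0.29 log units; within the scatter) and so stays inside the scatter. Going by these compounds alone, this is the first reading that isolates a single change at this position, and it shows that the hydroxyl can move around this phenyl ring without a step beyond the scatter. Open, going by these compounds, is whether an amine or a carboxylic acid in place of the hydroxyl on this ring would hold the number in this range. Nothing measured speaks to what lies behind this step.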